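A few compounds are considered here, and "the series" means these few. Any claim that something is new, unique, unknown or untested is made for them only; others in the source may bear on it.

Measured compounds in an ADME assay on MT4 cells (Homo sapiens) for cytotoxicity, read by MTT assay, with a stated time of 5 days; on this read-out lower numbers stand for higher toxicity in this test and higher numbers for lower toxicity in this test:
Compound 1 `Cc1cccc(Cn2cc(CNC(=O)c3cnc(Nc4ccc(C#N)cc4)cc3Oc3c(C)cc(C)cc3C)nn2)c1` gives 114000 nM.
Compound 2 `Cc1cc(C)c(Oc2cc(Nc3ccc(C#N)cc3)ncc2C(=O)NCc2cn(Cc3ccc(F)cc3)nn2)c(C)c1` gives >= 153000 nM, which is a limit of the assay rather than a number.
Compound 3 `Cc1cc(C)c(Oc2cc(Nc3ccc(C#N)cc3)ncc2C(=O)NCc2cn(Cc3ccc([N+](=O)[O-])cc3)nn2)c(C)c1` gives >= 139000 nM, also a limit of the assay rather than a number.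

Compound 3 thus stands at the limit of >= 139000 nM in this assay, at which 1 of the 3 values shown sits, and one further value shown is also a limit. The unmeasured compound 4 `Cc1cc(C)c(Oc2cc(Nc3ccc(C#N)cc3)ncc2C(=O)NCc2cn(CC(=O)N3CCOCC3)nn2)c(C)c1` differs from compound 3 by (morpholin-4-yl)carbonyl in place of 4-nitrophenyl on a saturated chain carbon bound to an aromatic nitrogen. The measured steps all exchange the group on that same saturated chain carbon: an at least 1.3-fold higher number from compound 1 to compound 2 (0.12 log units; that floor lies within the scatter) and an at least 1.2-fold higher number from compound 1 to compound 3 (0.08 log units; that floor lies within the scatter) are both small, while a step that the two limits leave unreadable from compound 2 to compound 3. None of them brings in a (morpholin-4-yl)carbonyl group, so no step beyond the scatter is expected in this assay. Compound 4 is therefore expected to give about 150000 nM, between 80000 nM and 300000 nM. The expected step is a step that the limit leaves unreadable from compound 3 to compound 4, and a limit rather than a number is likely.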

Compound 4, half-maximal cytotoxic concentration: 181000 nM
For compound 4 the middle estimate is 1.2-fold (0.08 log units) below the measured one; the range from low to high includes it.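

In this assay the saturated chain carbon bound to an aromatic nitrogen proves to accept more than a benzene ring: (morpholin-4-yl)carbonyl, with its non-aromatic ring, gives a 1.6-fold higher number from compound 1 to compound 4 (0.20 log units; within the scatter) and so no real separation from the 3-methylphenyl of compound 1. Losing the aromatic ring at this place therefore brings no measurable rise in toxicity in this test. The steps to compound 4 from compound 2 and from compound 3 cannot be read, as the values of those two compounds are limits of the assay.

Still open, on these data alone, is whether any group on this carbon can move the number beyond the scatter. A simple amine, a carboxylic acid or a longer chain there would test this.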